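Trimming a branched amine chain on a shared core

This account rests on a few compounds, and the source may have more. Where it says the series, first, only, none or still open, it means among the compounds named here.

Of the compounds shown here, two built on one shared core have been measured in an assay on cell membranes for displacement of a labelled ligand from corticotropin-releasing factor receptor 1 (Rattus norvegicus); a higher number here means a weaker inhibitor, a lower number a stronger inhibitor. Compound 1 `CCCCN(CCC)c1nc(C)nc2c(-c3ccc(OC)nc3C)c(C)nn12` gives 2.4 nM. Among the compounds with values here, compound 2 `CCCCC(C)Nc1nc(C)nc2c(-c3ccc(OC)nc3C)c(C)nn12` gives 5.1 nM, the higher of the two numbers, so of this pair it is the weaker inhibitor; the only measured step, a 2.1-fold higher number from compound 1 to compound 2 (0.33 log units; beyond the scatter), separates them. Compound 3 `CCC[C@H](C)Nc1nc(C)nc2c(-c3ccc(OC)nc3C)c(C)nn12` has not yet been measured. It differs from compound 2 in a single place: 1-methylbutyl in place of 1-methylpentyl on a nitrogen on an aromatic ring. In plain terms, the chain on the nitrogen on the aromatic ring becomes shorter, and its branching point carries a defined stereocentre. Within the data shown here, no measured step covers a change of this kind: the step from compound 1 to compound 2 exchanged a nitrogen bearing two chains for one bearing a single branched chain, a different sort of alteration, and even that was modest in size. Nothing in these numbers tells whether a shorter branched chain helps or hurts, so the expectation is a step of a 1.2-fold higher number from compound 2 to compound 3 (0.07 log units; within the scatter) that stays within the scatter, or at most a small move in either direction. Compound 3 is therefore estimated at 6 nM, with a range from 2.5 nM to 15 nM.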

Compound 3, half-maximal inhibitory concentration: 4.5 nM
Beside the measured number, compound 3's estimate is 1.3-fold (0.12 log units) above it; the measured number falls inside the stated range.
By their numbers in this assay, from the lowest: compounds 1, 3 and 2 (each within the scatter of the next, the first and the last beyond it).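

In this assay the shortening gives a 1.1-fold lower number from compound 2 to compound 3 (0.05 log units; within the scatter), so on this nitrogen on an aromatic ring, 1-methylbutyl and 1-methylpentyl cannot be told apart, even though the change also brings in a defined stereocentre. Set against the two-chain butyl(propyl)amino group, (1-methylbutyl)amino gives a 1.9-fold higher number from compound 1 to compound 3 (0.27 log units; within the scatter), whereas the earlier comparison with (1-methylpentyl)amino lay just beyond the scatter. Replacing the two chains with one branched chain therefore need not produce a readable difference, and that earlier gap should not be read as a firm rule for every single branched chain at this place.

Still open, as far as these compounds go, is whether a shorter 1-methylpropyl chain, a longer 1-methylhexyl chain or the mirror-image form of 1-methylbutyl would stay this close, and how the shorter chain and the defined stereocentre each contribute to the result for compound 3. No outside evidence bears on why these chains give such similar numbers.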